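Cinnamate esters in a mouse whole-animal screen

The source may report more compounds than this note shows. Statements on the series, on what has been measured and on what is new or still open speak of the compounds shown alone.

Measured so far, in a functional assay on the whole organism (strain Kunming) with Mus musculus as the target, with a stated time of 0.5 h, at a dose of 300 mg/kg by the intraperitoneal route; on this read-out higher numbers stand for a weaker effect at the one dose given and lower numbers for a stronger effect:
compound 1 `COc1cc(OC)c(OC)cc1/C=C/COC(=O)/C=C/c1c(OC)ccc(OC)c1OC`: 100%
compound 2 `COc1cc(OC)c(OC)cc1/C=C/COC(=O)/C=C/c1ccccc1C(F)(F)F`: 100%
compound 3 `COc1cc(OC)c(OC)cc1/C=C/COC(=O)/C=C/c1ccc(OC)c(OC)c1OC`: 100%

All three compounds share the same ester-linked core and differ only in the aromatic ring on the cinnamate side. On the numbers shown, compound 2 stands level with compound 1 and with compound 3 at the digits reported; the nearest neighbour is compound 1 and the furthest is compound 3, and neither gap goes beyond the usual scatter of this assay. Going by the values given here, nothing so far separates one ring from another on this read-out.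

The next compound, compound 4 `COc1cccc(/C=C/C(=O)OC/C=C/c2cc(OC)c(OC)cc2OC)c1`, is to be measured in this assay. It is derived from compound 2 by one change: 3-methoxyphenyl in place of 2-(trifluoromethyl)phenyl on a double-bonded chain carbon bound to a double-bonded chain carbon.

Among the compounds with values here, no step between two measured compounds is available to size this change. The three measured compounds give the same value whatever aromatic ring is present, so the step of no change at the digits printed from compound 2 to compound 4 (within the scatter) is expected to be none beyond the scatter, with any drift more likely downward than upward because compound 2 gives 100% and that leaves no room above it. Compound 4 is therefore estimated at 100%, with a range from 85% to 100%.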

Compound 4, a percentage reported as activity, at one dose (the size of the read-out at that dose, not a potency): 100%
Estimate against measurement, compound 4: no gap at the digits printed; measured number inside the range.
By their numbers in this assay, from the lowest: compounds 1, 2, 3 and 4 (each within the scatter of the next).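

In this assay, going by these compounds alone, 3-methoxyphenyl in place of 2-(trifluoromethyl)phenyl on a double-bonded chain carbon bound to a double-bonded chain carbon gives no change at the digits printed from compound 2 to compound 4 (within the scatter), the first step that can be read directly between two measured compounds. At this position, a group with 3 fluorine and 0 hydrogen-bond acceptors and a group with 1 oxygen and 1 hydrogen-bond acceptor therefore read alike at the one dose given, so this exchange produces no visible effect on the read-out. No measurement available here bears on why the two groups read alike.

The compounds shown leave open whether the read-out can respond to any change at this position, since a single-dose value is not a potency and no step beyond the scatter is yet available for comparison. Also unresolved is whether an amine or a carboxylic acid on this aromatic ring would move the read-out away from that of compound 4 at 100% in this assay.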